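Hydroxamate chain length on the shared core

This account rests on a few compounds, and the source may have more. Where it says the series, first, only, none or still open, it means among the compounds named here.

Measured compounds:
compound 1 `Nc1ncnc2c1c(-c1cnc3[nH]ccc3c1)nn2CCCCCCC(=O)NO` gives 19800 nM
compound 2 `Nc1ncnc2c1c(-c1cnc3[nH]ccc3c1)nn2CC(=O)NO` gives > 150000 nM
compound 3 `Nc1nc2cc(-c3nn(CCCCCCC(=O)NO)c4ncnc(N)c34)ccc2o1` gives 11900 nM

In a functional assay on MCF7 cells (Homo sapiens) for inhibition, read by MTT assay, with a stated time of 72 h (on this read-out lower numbers stand for stronger inhibition and higher numbers for weaker inhibition), compound 1 gives 19800 nM. Compound 3, with its different ring pair on the aromatic carbon, gives 11900 nM in this assay, and the step of a 1.7-fold lower number from compound 1 to compound 3 (0.22 log units; within the scatter) shows the two within the usual scatter. For compound 2 only a limit of this assay is known, > 150000 nM. Compound 2 thus stands at the weak end of the numbers shown, as evidence the limit of > 150000 nM in this assay, at which 1 of the 3 values shown sits, records, and the step of an at least 7.5-fold higher number from compound 1 to compound 2 (0.87 log units; beyond the scatter) is the only measured step bearing on the chain.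

Compound 4 `Nc1ncnc2c1c(-c1cnc3[nH]ccc3c1)nn2CCC(=O)NO` differs from compound 2 by (hydroxycarbamoyl)methyl in place of hydroxycarbamoyl on a saturated chain carbon bound to an aromatic nitrogen. The chain grows toward that of compound 1, though it stays much shorter. Since the shortening from compound 1 to compound 2 gave an at least 7.5-fold higher number from compound 1 to compound 2 (0.87 log units; beyond the scatter), one added carbon is expected to move the number only partly back, so the expected step is an at least 1.5-fold lower number from compound 2 to compound 4 (0.17 log units; that floor lies within the scatter). Compound 4 is estimated at 100000 nM, within 35000 nM to 300000 nM, with a fair chance that this assay again reports only a limit.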

Compound 4, half-maximal inhibitory concentration: > 150000 nM
Compound 4 ended at the assay's limit; the forecaster's own chance of this, stated with the estimate: 45%; middle value at least 1.5-fold (0.17 log units) away from the limit.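

Compound 4 joins compound 2 at the weak end of this assay, which shows that the loss is not confined to the hydroxycarbamoyl chain of compound 2: the limit of > 150000 nM in this assay, at which 2 of the 4 values shown sit.

The result for compound 4 is a limit and not a number, and the step from compound 2, which joins two limits, cannot be read. Measured against the longer chain, 2-(hydroxycarbamoyl)ethyl gives an at least 7.5-fold higher number from compound 1 to compound 4 (0.87 log units; beyond the scatter), so this position now has two short chains that both stand clearly apart from compound 1.

Which chain length between those of compound 4 and compound 1 first gives a readable number remains open, as does the effect of a longer chain than that of compound 1. Also open, as far as these compounds go, is whether a carboxylic acid in place of the hydroxycarbamoyl end would change the reading in this assay.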